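This account rests on a few compounds, and the source may have more. Where it says the series, first, only, none or still open, it means among the compounds named here.

Among the measured compounds shown here, compound 1 `Nc1ccccc1NC(=O)c1ccc(CSC(=S)N2CCc3ccccc32)cc1` and compound 2 `CN(Cc1cccnc1)C(=S)SCc1ccc(C(=O)Nc2ccccc2N)cc1` share one core and are the only measured members of the set. For the measured compounds named here, in a functional assay on MGC-803 cells (Homo sapiens) for antiproliferative activity, read by CCK-8 assay, with a stated time of 72 h, tested at 2 uM (on this read-out higher numbers stand for a stronger effect at the one concentration tested and lower numbers for a weaker effect), compound 1 gives 44% and compound 2 gives 45.9%; the step of a number 1.9 percentage points higher from compound 1 to compound 2 (within the scatter) lies within the scatter, so compound 1 stands at the same level as the one other number known. Compound 3 `Nc1ccccc1NC(=O)c1ccc(CSC(=S)N2CCc3ccc([N+](=O)[O-])cc32)cc1` differs from compound 1 by nitro in place of hydrogen on an aromatic carbon. Going by the values given here, no measured step touches this place; the only step known, a number 1.9 percentage points higher from compound 1 to compound 2 (within the scatter), alters the amine on the thiocarbonyl carbon and stays within the scatter, so nothing beyond the scatter is expected in this assay. A step of no change at the digits printed from compound 1 to compound 3 (within the scatter) is therefore expected. For compound 3 the estimate is 44%, ranging from 32% to 56%.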

Compound 3, a percentage reported as inhibition, at one concentration (the size of the read-out at that concentration, not a potency): 30.6%
The estimate for compound 3 lay 13.4 percentage points above the measured number; the whole stated range lies above it.
By their numbers in this assay, from the lowest: compound 3; then compounds 1 and 2 (each within the scatter of the next).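

Nitro in place of hydrogen on this aromatic carbon gives a number 13.4 percentage points lower from compound 1 to compound 3 (beyond the scatter) in this assay and is the first step in the series to pass beyond the scatter. Among the compounds shown here, this place therefore responds to substitution, while the one earlier step, on the amine at the thiocarbonyl carbon, did not leave the scatter. Nothing at hand explains the lower number. One substituent at one place cannot show whether any group here lowers the number or nitro alone does so. As far as these compounds go, an amine or a methoxy group on the same aromatic carbon remains open.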